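Removing the Benzyl Ester from Compound 3

The compounds below may be only part of what the source reports. "The series", "measured", "known", "first", "only" and "open" are said of these compounds alone.

Compound 3 `CC(C)C[C@H](NC(=O)CN(c1nc(Cl)nc2[nH]cnc12)C1CC1)C(=O)OCc1ccccc1` was measured in a functional assay on the whole organism (Tail, strain ICR) with Mus musculus as the target, in the tail flick test, with a stated time of 30 min, at a dose of 25 umol/kg by the oral route (a lower number here means a weaker effect, a higher number a stronger effect of the compound at the dose given), where compound 3 gives 33.9%. That is the highest of the three numbers seen so far. Compound 1 `NCCCC[C@H](NC(=O)CN(c1nc(Cl)nc2[nH]cnc12)C1CC1)C(=O)OCc1ccccc1` gives 26.1% in this assay, and the step of a number 7.8 percentage points higher from compound 1 to compound 3 (within the scatter) stays within the scatter. Compound 2 `O=C(CN(c1nc(Cl)nc2[nH]cnc12)C1CC1)NCC(=O)OCc1ccccc1` gives 18.7%, and the step of a number 15.2 percentage points higher from compound 2 to compound 3 (beyond the scatter) goes beyond the scatter. Compound 4 `CC(C)C[C@H](NC(=O)CN(c1nc(Cl)nc2[nH]cnc12)C1CC1)C(=O)O` differs from compound 3 in one place: hydrogen in place of benzyl on an oxygen next to a carbonyl group. None of the three measured steps touches that oxygen; all of them alter the saturated chain carbon, so they give no direct guide to the size or direction of this change. Within the data shown here, with no step to lean on, the expectation for compound 4 is kept close to compound 3, with a wide margin: the step of a number 7.9 percentage points lower from compound 3 to compound 4 (within the scatter) is expected, which on the middle number would be nothing beyond the scatter. Compound 4 is therefore expected to give about 26% in this assay, somewhere between 10% and 42%.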

Compound 4, a percentage reported as activity, at one dose (the size of the read-out at that dose, not a potency): 23.4%
The estimate for compound 4 lay 2.6 percentage points above the measured number, and the stated range covers the measured number.
By their numbers in this assay, from the lowest: compounds 2, 4, 1 and 3 (each within the scatter of the next, the first and the last beyond it).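

Among these compounds, this is the first change made at the ester oxygen rather than on the saturated chain carbon. Replacing benzyl with hydrogen, which turns the benzyloxycarbonyl group into a carboxy group, gives (a number 10.5 percentage points lower from compound 3 to compound 4 (beyond the scatter)) in this assay. The benzyl group therefore matters at this position, but it is not required for a reading, since compound 4 still gives 23.4%. Nothing measured here explains the step.

Still open, as far as these compounds go, is whether a smaller ester, such as a methyl or ethyl group on that oxygen, would stay near compound 3 or fall towards compound 4. From the compounds shown here alone, it is also open whether the same swap would have a similar effect with 4-aminobutyl or hydrogen in place of isobutyl on the chain carbon.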